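The source may report more compounds than this note shows. Statements on the series, on what has been measured and on what is new or still open speak of the compounds shown alone.

Measured compounds: compound 1 `CN(C(=O)NC(=O)c1ccc(F)c(F)c1)c1nc(C(F)(F)F)c(C(=O)N/N=C/c2ccccc2C(F)(F)F)s1` gives 9.24 ug/mL; compound 2 `CN(C(=O)NC(=O)c1ccc(Cl)c(Cl)c1)c1nc(C(F)(F)F)c(C(=O)N/N=C/c2ccc([N+](=O)[O-])cc2)s1` gives 5.12 ug/mL; compound 3 `CN(C(=O)NC(=O)c1ccc(F)c(F)c1)c1nc(C(F)(F)F)c(C(=O)N/N=C/c2cccc(C(F)(F)F)c2)s1` gives 4.21 ug/mL. All three values come from a functional assay on HeLa cells (Homo sapiens) for inhibition, read by MTT assay, with a stated time of 72 h; a lower number here means a stronger inhibitor, a higher number a weaker inhibitor.

Compound 3 has the lowest number of the three. Its nearest neighbour is compound 2, whose value sits within the scatter of compound 3, so no order can be claimed between those two. Among the measured compounds shown here, compound 1 sits further away: the one measured step, a 2.2-fold lower number from compound 1 to compound 3 (0.34 log units; beyond the scatter), is a modest change that lies beyond the scatter.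

Compound 4 `CN(C(=O)NC(=O)c1ccc(F)c(F)c1)c1nc(C(F)(F)F)c(C(=O)N/N=C/c2ccc([N+](=O)[O-])cc2)s1` differs from compound 3 in a single place: 4-nitrophenyl in place of 3-(trifluoromethyl)phenyl on a carbon with a double bond to nitrogen. For the measured compounds named here, no measured step covers this particular exchange. The only indirect light comes from compound 2, which already carries the 4-nitrophenyl group but on a core bearing a dichlorophenyl amide rather than the difluorophenyl amide of compounds 1, 3 and 4; the values of compound 2 and compound 3 show no separation beyond the scatter. On that basis compound 4 is expected to land near compound 3, with no step beyond the scatter in either direction, so a 1.3-fold higher number from compound 3 to compound 4 (0.12 log units; within the scatter) is the expected change in this assay. The estimate for compound 4 is 5.5 ug/mL, with a range from 2.5 ug/mL to 12 ug/mL.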

Compound 4, half-maximal inhibitory concentration: 5.08 ug/mL
Compound 4: the middle estimate sits 1.1-fold (0.03 log units) above what was measured; measured number inside the range.
By their numbers in this assay, from the lowest: compounds 3, 4, 2 and 1 (each within the scatter of the next, the first and the last beyond it).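

In this assay, a 1.2-fold higher number from compound 3 to compound 4 (0.08 log units; within the scatter) shows that, at this carbon with a double bond to nitrogen, 4-nitrophenyl and 3-(trifluoromethyl)phenyl cannot be told apart, even though they differ in their atoms and in hydrogen-bond acceptor count. The same exchange against 2-(trifluoromethyl)phenyl gives a 1.8-fold lower number from compound 1 to compound 4 (0.26 log units; within the scatter) and also stays within the scatter, so only the earlier step between the two trifluoromethyl isomers separates any groups at this place. Among the compounds shown here, the result also gives the first direct reading of the other varied place: a 1.0-fold lower number from compound 2 to compound 4 (0.00 log units; within the scatter) shows no separation between 3,4-difluorophenyl and 3,4-dichlorophenyl on the carbonyl carbon, at least with 4-nitrophenyl on the shared core, and no measurement offered here explains any of these steps.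

On these data alone, whether the two halogen patterns also stay together with a trifluoromethylphenyl group remains open, since that pairing can be read only for 4-nitrophenyl. As far as these compounds go, it is also open how this place would respond to a phenyl ring carrying an amine or a carboxylic acid, or to a longer chain in place of the ring.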